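The source may hold more compounds than are shown below. What is called first, only, known or untested is meant among the compounds shown, and "the series" means these compounds.

Measured compounds:
- Compound 1, `FC(F)(F)c1ccc(CSc2nc(Nc3cccc(C(F)(F)F)c3)c3ccccc3n2)cc1`: 11700 nM
- Compound 2, `FC(F)(F)c1ccc(CSc2nc(Nc3cccc(Br)c3)c3ccccc3n2)cc1`: 18300 nM
- Compound 3, `O=[N+]([O-])c1ccc(Nc2nc(SCc3ccc(C(F)(F)F)cc3)nc3ccccc23)cc1`: 16600 nM

All three share the same core and were tested in a functional assay on HGC-27 cells (Homo sapiens) for cytotoxicity, read by MTT assay, with a stated time of 72 h; a higher number here means a weaker inhibitor, a lower number a stronger inhibitor. Compound 2 gives the highest number of the three, but every gap is within the usual scatter: the step of a 1.6-fold higher number from compound 1 to compound 2 (0.19 log units; within the scatter) and the step of a 1.1-fold lower number from compound 2 to compound 3 (0.04 log units; within the scatter) are both small, and the step of a 1.4-fold higher number from compound 1 to compound 3 (0.15 log units; within the scatter) is small as well, so none of the three can be called weaker or stronger than another.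

Compound 4, `Fc1ccc(Nc2nc(SCc3ccc(C(F)(F)F)cc3)nc3ccccc23)cc1Cl`, has not yet been measured. It differs from compound 2 in one place: 3-chloro-4-fluorophenyl in place of 3-bromophenyl on a nitrogen on an aromatic ring

Within the data shown here, two measured steps bear on this change. The step of a 1.6-fold higher number from compound 1 to compound 2 (0.19 log units; within the scatter) exchanged one group on this same ring, and the step of a 1.1-fold lower number from compound 2 to compound 3 (0.04 log units; within the scatter) exchanged the whole ring, each without moving the number beyond the scatter. With that record, no step beyond the scatter is expected in this assay for this exchange either, in either direction. Compound 4 is therefore estimated at 15000 nM, with a range from 7000 nM to 32000 nM, which corresponds to an expected step of a 1.2-fold lower number from compound 2 to compound 4 (0.09 log units; within the scatter).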

Compound 4, half-maximal inhibitory concentration: 14700 nM
The estimate for compound 4 lay 1.0-fold (0.01 log units) above the measured number, and the stated range covers the measured number.
By their numbers in this assay, from the lowest: compounds 1, 4, 3 and 2 (each within the scatter of the next).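

In this assay, a 1.2-fold lower number from compound 2 to compound 4 (0.10 log units; within the scatter) and a 1.1-fold lower number from compound 3 to compound 4 (0.05 log units; within the scatter) and a 1.3-fold higher number from compound 1 to compound 4 (0.10 log units; within the scatter) all stay within the scatter, so 3-chloro-4-fluorophenyl cannot be told apart from any of the earlier groups on this nitrogen. The earlier rings each carried a bromo, a nitro or a trifluoromethyl group, whereas this ring carries both a chlorine and a fluorine, and the number still does not move beyond the scatter in any of the three comparisons. Nothing measured here explains this lack of separation, so it stands as an observation about these four compounds and not as a rule for the position.

Going by these compounds, it remains open whether any group on this nitrogen can move the number beyond the scatter, for example a phenyl ring bearing an amine or a carboxylic acid, or a longer carbon chain in place of the ring. Among these compounds, the four compounds also vary only this ring, so they say nothing about how changes elsewhere on the shared core would affect the number.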